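Three Compounds at the Limit, and a Fourth to Test

The source may hold more compounds than are shown below. What is called first, only, known or untested is meant among the compounds shown, and "the series" means these compounds.

Of the compounds shown here, three sharing one core have been read in a functional assay on MDA-MB-231 cells (Homo sapiens) for antiproliferative activity, read by MTT assay, with a stated time of 24 h; on this read-out higher numbers stand for weaker inhibition and lower numbers for stronger inhibition. Compound 1 `Cc1ccccc1NNC(=O)c1ccccc1NS(=O)(=O)c1cnc(O)nc1O` gives > 20000 nM, which is a limit and not a number. Compound 2 `O=C(NNc1ccccc1F)c1ccccc1NS(=O)(=O)c1cnc(O)nc1O` gives > 20000 nM, again a limit. Compound 3 `O=C(NNc1ccc(F)cc1)c1ccccc1NS(=O)(=O)c1cnc(O)nc1O` gives > 20000 nM, also a limit. Compound 3 therefore has no number of its own and stands with the other two, as the set shows: the limit of > 20000 nM in this assay, at which 3 of the 3 values shown sit.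

Compound 4 `O=C(NNC(=O)c1ccccc1NS(=O)(=O)c1cnc(O)nc1O)c1ccccc1Cl` has not yet been measured. Its difference from compound 3 is (2-chlorophenyl)carbonyl in place of 4-fluorophenyl on an amine nitrogen. In words, (2-chlorophenyl)carbonyl replaces 4-fluorophenyl on an amine nitrogen.

For the measured compounds named here, three measured steps bear on this change: a step that the two limits leave unreadable from compound 1 to compound 2, a step that the two limits leave unreadable from compound 1 to compound 3 and a step that the two limits leave unreadable from compound 2 to compound 3. None has a readable size, and none of them brings in a carbonyl, so they offer no measured guide to the new group. No step beyond the usual scatter is therefore expected, and no direction can be assigned. The expected outcome is a step that the limit leaves unreadable from compound 3 to compound 4. Compound 4 is estimated at 25000 nM, with an expected range from 6000 nM to 60000 nM. A reading that gives only a limit is expected to be the likeliest result.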

Compound 4, half-maximal inhibitory concentration: 8310 nM
Compound 4: middle estimate off by 3.0-fold (0.48 log units), on the high side; the measured number falls inside the stated range.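

In this assay, for the compounds shown here, (2-chlorophenyl)carbonyl on the amine nitrogen in place of 4-fluorophenyl gives an at least 2.4-fold lower number from compound 3 to compound 4 (0.38 log units; beyond the scatter), the first change at this position whose size can be read at all, and compound 4 is the only one of the set with a number of its own. The same group in place of 2-fluorophenyl gives an at least 2.4-fold lower number from compound 2 to compound 4 (0.38 log units; beyond the scatter), and in place of 2-methylphenyl it gives an at least 2.4-fold lower number from compound 1 to compound 4 (0.38 log units; beyond the scatter), while the steps among compound 1, compound 2 and compound 3 themselves cannot be read. All three new steps are minimum sizes, bounded from one side only: the limit of > 20000 nM in this assay, at which 3 of the 4 values shown sit.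

Compound 4 brings in the carbonyl and the chlorine at once, so the compounds shown leave open which of the two carries the step, a question that a plain phenylcarbonyl, a (4-fluorophenyl)carbonyl or a 2-chlorophenyl on the same amine nitrogen would address. From the compounds shown here alone, it is also open whether an acetyl group, which has no aromatic ring, would still give a number rather than a limit in this assay.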